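Swapping a triazole for a sulfonamide in HeLa cytotoxicity

A few compounds are considered here, and "the series" means these few. Any claim that something is new, unique, unknown or untested is made for them only; others in the source may bear on it.

Measured compounds:
compound 1 `CN1CCN(Cc2nnc(-c3cc(S(N)(=O)=O)c(SCc4ccccc4)cc3Cl)o2)CC1` gives 75000 nM
compound 2 `NC(=O)c1cn(Cc2nnc(-c3cc(S(N)(=O)=O)c(SCc4ccccc4)cc3Cl)o2)nn1` gives 75000 nM
compound 3 `COc1ccc(-c2cn(Cc3nnc(-c4cc(S(N)(=O)=O)c(SCc5ccccc5)cc4Cl)o3)nn2)cc1` gives 68000 nM

In a functional assay on HeLa cells (Homo sapiens) for cytotoxicity, read by MTT assay, with a stated time of 72 h (on this read-out lower numbers stand for stronger inhibition and higher numbers for weaker inhibition), compound 2 stands level with compound 1 and within the scatter of compound 3, so all three numbers sit together and none can be called stronger or weaker. Compound 4 `NS(=O)(=O)c1cc(-c2nnc(CNS(=O)(=O)c3ccc(Cl)cc3)o2)c(Cl)cc1SCc1ccccc1` differs from compound 2 by ((4-chlorophenyl)sulfonyl)amino in place of 4-carbamoyl-1H-1,2,3-triazol-1-yl on a saturated chain carbon bound to an aromatic carbon. The measured steps that bear on this are no change at the digits printed from compound 1 to compound 2 (within the scatter) and a 1.1-fold lower number from compound 2 to compound 3 (0.04 log units; within the scatter); both alter the same part of the shared core, and neither moved the number beyond the scatter. Compound 4 is therefore expected to show a step of a 1.0-fold lower number from compound 2 to compound 4 (0.02 log units; within the scatter), that is, no change beyond the scatter. The estimate for compound 4 is 72000 nM, with an expected range from 35000 nM to 150000 nM.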

Compound 4, half-maximal inhibitory concentration: 24000 nM
The estimate for compound 4 lay 3.0-fold (0.48 log units) above the measured number; the measured number lies below the stated range.
By their numbers in this assay, from the lowest: compound 4; then compounds 3, 1 and 2 (each within the scatter of the next).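

In this assay, going by these compounds alone, ((4-chlorophenyl)sulfonyl)amino on this saturated chain carbon bound to an aromatic carbon gives a 3.1-fold lower number from compound 2 to compound 4 (0.49 log units; beyond the scatter) and also a 3.1-fold lower number from compound 1 to compound 4 (0.49 log units; beyond the scatter) so this place can respond to its substituent, which the earlier compounds did not show. Within the data shown here, the step is modest, but it is the first here to pass beyond the scatter. No available evidence explains the difference.

As far as these compounds go, whether the step belongs to the sulfonylamino link or to the 4-chlorophenyl ring remains open. A phenylsulfonylamino group, without the chlorine, and a benzoylamino group, with a carbonyl in place of the sulfonyl, would help separate the two.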